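Ether to Thioether: From Compound 1 to Compound 4

The source may report more compounds than this note shows. Statements on the series, on what has been measured and on what is new or still open speak of the compounds shown alone.

Measured so far:
- compound 1 `Nc1cc(N)c2nc(-c3ccccc3)c(Oc3ccc(Cl)c(Cl)c3)nc2c1`: 28800 nM
- compound 2 `COc1cc(CNc2nc3cc(N)cc(N)c3nc2-c2ccccc2)cc(OC)c1OC`: 7760 nM
- compound 3 `CCOC(=O)[C@H](CCC(=O)O)NC(=O)c1ccc(Oc2nc3cc(N)cc(N)c3nc2-c2ccccc2)cc1`: 53700 nM

All three were tested in a functional assay on SK-MEL-5 cells (Homo sapiens) for inhibition, read by sulforhodamine B assay, with a stated time of 48 h; a higher number here means a weaker inhibitor of growth, a lower number a stronger inhibitor of growth. Compound 1 gives 28800 nM, the second highest of the three numbers. Compound 3 gives 53700 nM, and the gap between compound 1 and compound 3 lies within the usual scatter of repeated measurements, so the two cannot be told apart. Compound 2 gives 7760 nM, a lower number than compound 1 by a margin beyond the scatter; the structural differences between these two compounds are several at once, so no single change can be tied to that gap.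

Compound 4 `Nc1cc(N)c2nc(-c3ccccc3)c(Sc3ccc(Cl)c(Cl)c3)nc2c1` has not yet been measured. It differs from compound 1 in one place: (3,4-dichlorophenyl)sulfanyl in place of 3,4-dichlorophenoxy on an aromatic carbon. This swap keeps the count of heavy atoms, the single aromatic ring, the two chlorines and the one hydrogen-bond acceptor, and changes only the linking atom. Within the data shown here, with no measured pair showing what such a swap does here, the expected step of a 1.2-fold lower number from compound 1 to compound 4 (0.06 log units; within the scatter) is none beyond the scatter, in no particular direction. Compound 4 is therefore estimated at 25000 nM, with a range from 8000 nM to 80000 nM.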

Compound 4, concentration for total growth inhibition: 95500 nM
Beside the measured number, compound 4's estimate is 3.8-fold (0.58 log units) below it; measured number above the stated range.
By their numbers in this assay, from the lowest: compound 2; then compounds 1, 3 and 4 (each within the scatter of the next, the first and the last beyond it).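

In this assay, exchanging only the linking atom, oxygen for sulfur, gives a 3.3-fold higher number from compound 1 to compound 4 (0.52 log units; beyond the scatter) and so a weaker inhibitor of growth. Among these compounds, this is the first pair here that differs in one place, so it is the first direct reading of a change at this aromatic carbon. The two groups match in heavy atom count, in their ring and two chlorines, and in hydrogen-bond donors and acceptors, yet the step lies beyond the usual scatter of repeated measurements, so the identity of the linking atom alone can matter at this position. Nothing available here shows why the sulfur-linked compound is the weaker of the two, so the step stands as an observation without an explanation.

The compounds shown leave open how other links at this same carbon would behave, such as a methylene or a sulfonyl group carrying the same 3,4-dichlorophenyl ring. This single pair also cannot tell whether the oxygen-to-sulfur step would keep its direction and size with a different ring on the link, for instance a phenyl ring without the two chlorines.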